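The source may hold more compounds than are shown below. What is called first, only, known or untested is meant among the compounds shown, and "the series" means these compounds.

Compound 1 `COc1ccc2c(c1C)NC(=O)[C@]2(c1ccc(O)cc1)C1CCCCCC1`: 0.48 nM
Compound 2 `COc1ccc2c(c1C)NC(=O)C2(c1ccc(O)cc1)C1CCCCCC1`: 4.7 nM
Compound 3 `COc1ccc2c(c1C)NC(=O)[C@@]2(c1ccc(O)cc1)C1CCCCCC1`: not yet measured

Among the compounds with values here, in a functional assay on MCF7 cells (Homo sapiens) for cytotoxicity, read by WST assay, with a stated time of 72 h (a lower number here means a stronger inhibitor, a higher number a weaker inhibitor), compound 2 gives the higher of the two numbers so far, at 4.7 nM. The change to compound 3 is the two compounds have the same atoms and bonds; at least one stereo element is drawn with a configuration in one of them and without one in the other: 1 of 1 stereo elements differ; a stereocentre at a saturated ring carbon is drawn without a configuration in compound 2 and R in compound 3. Within the data shown here, one measured step bears on it: a 9.8-fold higher number from compound 1 to compound 2 (0.99 log units; beyond the scatter), which goes with the fact that one of compounds 1 and 2 is drawn with a defined configuration and the other without, at the place where they differ. Compound 1 is drawn S and compound 3 R, so with compound 1 at 0.48 nM, compound 3 is expected to sit above compound 2, by a step of similar or greater size. The estimated change is a 13-fold higher number from compound 2 to compound 3 (1.11 log units; beyond the scatter). Compound 3 is estimated at 60 nM, within a range of 10 nM to 500 nM.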

Compound 3, half-maximal inhibitory concentration: > 1000 nM
Compound 3: only a limit was reported; the forecaster's own chance of this, stated with the estimate: 10%; middle value at least 16-fold (1.22 log units) away from the limit.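

In this assay compound 3 gives > 1000 nM, which is a limit and not a number. Configuration at the saturated ring carbon separates the S and R forms far more sharply than the earlier pair suggested, with an at least 2000-fold higher number from compound 1 to compound 3 (3.31 log units; beyond the scatter), while the form drawn without a configuration stands apart from R with an at least 210-fold higher number from compound 2 to compound 3 (2.32 log units; beyond the scatter). Nothing else separates the S and R forms: the fact that compounds 1 and 3 differ only in the configuration as drawn

The limit leaves the true size of both steps open. Also open, going by these compounds, is whether S stays favoured with an amine or a carboxylic acid in place of the hydroxyl.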